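Two Fluoro-to-Hydrogen Steps in One Antiproliferative Series

The source may hold more compounds than are shown below. What is called first, only, known or untested is meant among the compounds shown, and "the series" means these compounds.

Compound 1 `CS(=O)(=O)c1ccc(Nc2ncc(F)c(Nc3nc4ccccc4s3)n2)cc1`: 3170 nM
Compound 2 `CS(=O)(=O)c1ccc(Nc2ncc(F)c(Nc3nc4ccc(F)cc4s3)n2)cc1`: > 50000 nM
Compound 3 `COc1ccc2nc(Nc3nc(Nc4ccc(S(N)(=O)=O)cc4)ncc3F)sc2c1`: 13000 nM

All three were tested in a functional assay on HeLa cells (Homo sapiens) for antiproliferative activity, read by MTT assay, with a stated time of 48 h; a higher number here means a weaker inhibitor, a lower number a stronger inhibitor. Compound 1 gives 3170 nM. For compound 2 the reading is only a limit of the assay, > 50000 nM. Compound 2 thus sits at the limit of > 50000 nM in this assay, at which 1 of the 3 values shown sits. The step of an at least 15-fold lower number from compound 2 to compound 1 (1.19 log units; beyond the scatter) corresponds to hydrogen in place of fluoro on an aromatic carbon. Compound 3 gives 13000 nM, the highest number among those measured; it differs from compound 2 in more than one place, and the difference between the two cores is not broken down here.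

Compound 4 `COc1ccc2nc(Nc3ccnc(Nc4ccc(S(N)(=O)=O)cc4)n3)sc2c1` has not been measured. It differs from compound 3 by hydrogen in place of fluoro on an aromatic carbon. This is the same kind of change as that from compound 2 to compound 1, but not the same: there the carbon lay on a six-membered aromatic ring of carbon only, part of a fused system of two rings, meta and para to a fused ring; here it lies on a six-membered aromatic ring with 2 nitrogen, ortho and para to a large group, two atoms from the ring nitrogen. Because the earlier step was an at least 15-fold lower number from compound 2 to compound 1 (1.19 log units; beyond the scatter), some movement is plausible, yet with the place so different a smaller step is expected. The expected step is a 1.2-fold higher number from compound 3 to compound 4 (0.09 log units; within the scatter). Compound 4 is estimated at 16000 nM, likely between 5000 nM and 50000 nM.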

Compound 4, half-maximal inhibitory concentration: 1730 nM
Compound 4: middle estimate off by 9.2-fold (0.97 log units), on the high side; measured number outside the range, below it.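

In this assay, hydrogen in place of fluoro on the six-membered aromatic ring with 2 nitrogen gives a 7.5-fold lower number from compound 3 to compound 4 (0.88 log units; beyond the scatter), the same direction as the earlier step on the core of compound 1, although the fluoro leaves a different place. For the compounds shown here, with only two pairs, this shows the direction holding in these compounds, not a rule for other cores, and the two sizes cannot be set against each other: the same change on two cores in this assay, an at least 15-fold lower number (1.19 log units; beyond the scatter) from compound 2 to compound 1 and a 7.5-fold lower number (0.88 log units; beyond the scatter) from compound 3 to compound 4; the limit leaves it open whether they differ Compound 2 reads > 50000 nM, which is a limit of the assay and not a number.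

The compounds shown leave open how the number would move if that aromatic carbon carried a chloro, a methyl or an amine rather than fluoro or hydrogen. They also leave open whether the step from fluoro to hydrogen would hold if the methoxy group of compound 3 and compound 4 gave way to a carboxylic acid or a longer chain.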